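The source may report more compounds than this note shows. Statements on the series, on what has been measured and on what is new or still open speak of the compounds shown alone.

Measured compounds, in a physicochemical assay for solubility, read by HPLC; a lower number here means a less soluble compound, a higher number a more soluble compound:
- compound 1, `CC(=O)NC[C@H]1CN(c2ccc(OC[C@@H](O)CNc3ccccc3)c(F)c2)C(=O)O1`: 124000 nM
- compound 2, `CC(=O)NC[C@H]1CN(c2ccc(OC[C@H](O)CNc3ccccc3)c(F)c2)C(=O)O1`: 296000 nM
- compound 3, `CC(=O)NC[C@H]1CN(c2ccc(OC[C@H](O)CNc3cccnc3)c(F)c2)C(=O)O1`: 10100000 nM

Compound 3 stands highest of the three numbers in this assay. Its nearest neighbour is compound 2, as seen in a 34-fold higher number from compound 2 to compound 3 (1.53 log units; beyond the scatter), and the widest gap is to compound 1, as seen in an 81-fold higher number from compound 1 to compound 3 (1.91 log units; beyond the scatter). Compounds 1 and 2 differ only in the drawn configuration, and even that small change gives a 2.4-fold higher number from compound 1 to compound 2 (0.38 log units; beyond the scatter), which rests on (the fact that compounds 1 and 2 differ only in the configuration as drawn).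

Compound 4, `CC(=O)NC[C@H]1CN(c2ccc(OC[C@@H](O)CNCCC(C)C)c(F)c2)C(=O)O1`, is not yet measured. Its change from compound 3 is 1-hydroxy-2-(isopentylamino)ethyl in place of 1-hydroxy-2-((pyridin-3-yl)amino)ethyl on a saturated chain carbon bound to an oxygen on an aromatic ring. For the measured compounds named here, no measured step swaps this aromatic ring for an open chain, so the guidance is indirect. The two steps that reach compound 3 show that changes at this end of the molecule can move the number a long way. A middle-sized downward step, a 3.4-fold lower number from compound 3 to compound 4 (0.53 log units; beyond the scatter), is expected, with wide uncertainty. Compound 4 is therefore estimated at 3000000 nM, between 400000 nM and 20000000 nM.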

Compound 4, solubility: 385000 nM
Compound 4: middle estimate off by 7.8-fold (0.89 log units), on the high side; the whole stated range lies above it.
By their numbers in this assay, from the lowest: compound 1; then compounds 2 and 4 (each within the scatter of the next); then compound 3.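

In this assay, with the drawn configuration held fixed, isopentyl in place of phenyl on the amine nitrogen gives only a modest change: a 3.1-fold higher number from compound 1 to compound 4 (0.49 log units; beyond the scatter). The isopentyl chain also stands level with the phenyl compound of the other configuration, a 1.3-fold higher number from compound 2 to compound 4 (0.11 log units; within the scatter), whereas a 26-fold lower number from compound 3 to compound 4 (1.42 log units; beyond the scatter) shows that the very high number of compound 3 does not carry over to this open chain, leaving pyridin-3-yl alone among these groups. Both of these last two steps also switch the drawn configuration, which by itself gives only a 2.4-fold higher number from compound 1 to compound 2 (0.38 log units; beyond the scatter): the fact that compounds 1 and 2 differ only in the configuration as drawn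

The compounds shown leave open whether pyridin-3-yl gives so high a number in the configuration drawn in compound 1. They also leave open how a pyridin-4-yl ring or a chain ending in a carboxylic acid on the amine nitrogen would read.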